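A few compounds are considered here, and "the series" means these few. Any claim that something is new, unique, unknown or untested is made for them only; others in the source may bear on it.

Measured compounds: compound 1 `CCOC(=O)C1=C(C)NC(C(OCC)OCC)=C(C(=O)OCC)C1c1cccc([N+](=O)[O-])c1` with 615 nM; compound 2 `COC(=O)C1=C(C)NC(C)=C(C(=O)OCC(C)[N+](=O)[O-])C1c1cccc([N+](=O)[O-])c1` with 111 nM; compound 3 `CCOC(=O)C1=C(C)NC(C)=C(C(=O)OC=O)C1c1cccc([N+](=O)[O-])c1` with 13900 nM.

In a functional assay on HEK293 cells for antagonist activity at Voltage-dependent L-type calcium channel subunit alpha-1D (Rattus norvegicus), read by FLIPR (on this read-out lower numbers stand for stronger inhibition and higher numbers for weaker inhibition), compound 2 gives the lowest of the three numbers. Its gap to compound 1 lies beyond the scatter, and its gap to compound 3 is wider still, so on these numbers compound 2 is the most potent of the measured set.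

Compound 4 `COC(=O)C1=C(C)NC(C)=C(C(=O)OCCCCc2ccc(OC)cc2)C1c1cccc([N+](=O)[O-])c1` differs from compound 2 in one place: 3-(4-methoxyphenyl)propyl in place of 1-nitroethyl on a saturated chain carbon bound to an oxygen next to a carbonyl group. Among the measured compounds shown here, no measured pair shows a step of this kind, so the expectation rests on compound 2 alone. The step is expected to be small, at most a modest drop in the number, and it may well stay within the scatter: the estimated step is a 1.4-fold lower number from compound 2 to compound 4 (0.14 log units; within the scatter). In this assay compound 4 is expected to give 80 nM, between 20 nM and 320 nM.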

Compound 4, half-maximal inhibitory concentration: 38 nM
Beside the measured number, compound 4's estimate is 2.1-fold (0.32 log units) above it; measured number inside the range.
By their numbers in this assay, from the lowest: compound 4; then compound 2; then compound 1; then compound 3.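

In this assay, the place on a saturated chain carbon bound to an oxygen next to a carbonyl group accepts the larger 3-(4-methoxyphenyl)propyl, with its aromatic ring, in place of 1-nitroethyl, giving a 2.9-fold lower number from compound 2 to compound 4 (0.47 log units; beyond the scatter). The nitro group of 1-nitroethyl is therefore not required here for inhibition on this read-out. No evidence available here accounts for the step.

Which part of the entering group carries the step remains open: the aromatic ring, the methoxy group or the chain. Also open, as far as these compounds go, is how 3-phenylpropyl, or a chain bearing an amine, would compare.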